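Swapping a Sulfur-Linked Group Near the Assay Limit

The source may hold more compounds than are shown below. What is called first, only, known or untested is meant among the compounds shown, and "the series" means these compounds.

Three related compounds have been tested so far in a functional assay on BGC-823 cells (Homo sapiens) for inhibition, read by MTT assay, with a stated time of 72 h; on this read-out higher numbers stand for weaker inhibition and lower numbers for stronger inhibition. Compound 1 `C[C@@H]1CCN(c2cc(-c3ccccc3)nc3ncnn23)C[C@@H]1N(C)c1ncnc2[nH]ccc12` gives > 100000 nM, which is a limit and not a number. Compound 2 `Cc1cc(N2CC[C@@H](C)[C@@H](N(C)c3ncnc4[nH]ccc34)C2)n2nc(SCc3csc4ccc(Cl)cc34)nc2n1` gives > 100000 nM, which is also a limit and not a number. For the measured compounds named here, compound 3 `CCc1cc(N2CC[C@@H](C)[C@@H](N(C)c3ncnc4[nH]ccc34)C2)n2ncnc2n1` gives 82200 nM, the only true number in the set. The data are therefore dominated by the limit of > 100000 nM in this assay, at which 2 of the 3 values shown sit.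

Compound 4 `COc1ccc(CSc2nc3nc(C)cc(N4CC[C@@H](C)[C@@H](N(C)c5ncnc6[nH]ccc56)C4)n3n2)cc1` has not yet been measured. It carries 4-methoxyphenyl in place of 5-chloro-1-benzothiophen-3-yl on a saturated chain carbon bound to a sulfur.

Going by the values given here, no measured step covers this change directly. The only one available is an at least 1.2-fold lower number from compound 1 to compound 3 (0.08 log units; that floor lies within the scatter), which puts ethyl in place of phenyl on an aromatic carbon at another place in the molecule, and it does not go beyond the scatter. Among the compounds with values here, with compound 3 at 82200 nM as the only number nearby, no clear step beyond the scatter is expected in this assay. The expected step is an at least 1.1-fold lower number from compound 2 to compound 4 (0.04 log units; that floor lies within the scatter). For compound 4 the estimated value is 90000 nM, with an expected range from 35000 nM to 200000 nM.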

Compound 4, half-maximal inhibitory concentration: 69900 nM
Compound 4: middle estimate off by 1.3-fold (0.11 log units), on the high side; the measured number falls inside the stated range.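

On a saturated chain carbon bound to a sulfur, 4-methoxyphenyl in place of 5-chloro-1-benzothiophen-3-yl gives a true number in this assay, and the change brings an at least 1.4-fold lower number from compound 2 to compound 4 (0.15 log units; that floor lies within the scatter). The real size of this step cannot be read, because the value of compound 2 is a limit and not a number: the limit of > 100000 nM in this assay, at which 2 of the 4 values shown sit. So the new result shows that a compound with a group on this sulfur can give a reading inside the range of the assay, but it does not establish a real gain in inhibition, and the number for compound 4 remains large on this read-out.

The compounds shown cannot separate what the entering methoxy group contributes from what the loss of 5-chloro-1-benzothiophen-3-yl contributes. A plain benzyl group or a 4-aminobenzyl group on the same sulfur would help to tell these apart, and would show whether the number at this position can move by more than the usual scatter.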